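Diacylhydrazine series: aryl exchange at the hydrazide carbonyl

A few compounds are considered here, and "the series" means these few. Any claim that something is new, unique, unknown or untested is made for them only; others in the source may bear on it.

Compound 1 `CCc1ccccc1C(=O)N(NC(=O)c1ccccc1)C(C)(C)C` gives 589 nM in an assay on cells for agonist activity at ecdysone receptor (Bombyx mori), read by a luciferase reporter, with a stated time of 24 h; on this read-out lower numbers stand for an effect already at smaller amounts and higher numbers for an effect only at larger amounts of compound; compound 2 `COc1ccccc1C(=O)N(NC(=O)c1ccccc1)C(C)(C)C` gives 525 nM. For the measured compounds named here, the only one-place step, a 1.1-fold lower number from compound 1 to compound 2 (0.05 log units; within the scatter), alters the other aryl group and stays within the scatter. Compound 3 `CC(C)(C)N(NC(=O)c1cccc(Br)c1)C(=O)c1ccccc1Cl` gives 191 nM, the lowest of the three numbers, beyond the scatter from both compound 1 and compound 2. Compound 4 `Cc1ccc(C)c(C(=O)NN(C(=O)c2ccccc2Cl)C(C)(C)C)c1` is not yet measured; it differs from compound 3 by 2,5-dimethylphenyl in place of 3-bromophenyl on a carbonyl carbon. Going by the values given here, no measured step touches this aryl, so the direction of the change cannot be drawn from the series; compound 3 supplies the anchor value. A step of a 2.1-fold higher number from compound 3 to compound 4 (0.32 log units; beyond the scatter) is expected, most likely near the scatter. Compound 4 is estimated at 400 nM, with a range from 130 nM to 1200 nM.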

Compound 4, half-maximal effective concentration: 1620 nM
Compound 4: middle estimate off by 4.1-fold (0.61 log units), on the low side; the measured number lies above the stated range.
By their numbers in this assay, from the lowest: compound 3; then compounds 2 and 1 (each within the scatter of the next); then compound 4.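

For the compounds shown here, replacing 3-bromophenyl with 2,5-dimethylphenyl on the carbonyl carbon gives an 8.5-fold higher number from compound 3 to compound 4 (0.93 log units; beyond the scatter) in this assay, the first reading of a change at this aryl group. Going by these compounds alone, this group is therefore sensitive to exchange, whereas the single step on the other aryl group, a 1.1-fold lower number from compound 1 to compound 2 (0.05 log units; within the scatter), stays within the scatter. Nothing measured here gives a reason for the step.

On these data alone, this single exchange removes the bromine and adds both methyl groups, so their separate contributions remain open. As far as these compounds go, how an aryl group carrying an amine or a carboxylic acid would read out at this carbonyl carbon also remains open.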